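This account rests on a few compounds, and the source may have more. Where it says the series, first, only, none or still open, it means among the compounds named here.

Three compounds have been measured in an assay on cells for inhibition of phosphatidylcholine:ceramide cholinephosphotransferase 2 (Homo sapiens), read by mass spectrometry, with stated times of 60 min and 30 min; on this read-out lower numbers stand for stronger inhibition and higher numbers for weaker inhibition:
compound 1 `CN(Cc1cc(C(F)(F)F)cc(C(F)(F)F)c1)C(=O)c1c(OCCCC(F)(F)F)c2ccccc2n(C)c1=O` gives 120 nM;
compound 2 `CCOc1cc(CN(C)C(=O)c2c(OCCCC3CCN(C(=O)OC(C)(C)C)CC3)c3ccccc3n(C)c2=O)cc(OCC)c1` gives 380 nM;
compound 3 `CN(Cc1cc(C(F)(F)F)cc(C(F)(F)F)c1)C(=O)c1c(OCCCC2CCCCC2)c2ccccc2n(C)c1=O` gives 480 nM.

Compound 3 carries the highest number of the three. Its gap to compound 2 lies within the usual scatter, so the two cannot be told apart. Among the compounds with values here, its gap to compound 1 is real: the one recorded step between two compounds that differ in a single place is a 4.0-fold higher number from compound 1 to compound 3 (0.60 log units; beyond the scatter).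

The next compound, compound 4 `CN(Cc1cc(C(F)(F)F)cc(C(F)(F)F)c1)C(=O)c1c(N2CCCCC2)c2ccccc2n(C)c1=O`, differs from compound 3 by piperidin-1-yl in place of 3-cyclohexylpropoxy on an aromatic carbon. Within the data shown here, no measured step covers this kind of change. Among the measured compounds shown here, the only step known at this place swaps the end of the chain, and all three measured compounds keep a chain of three saturated carbons between the aromatic oxygen and its terminal group; compound 4 has no such chain and no such oxygen. Because a 4.0-fold higher number from compound 1 to compound 3 (0.60 log units; beyond the scatter) already shows that altering the far end of the chain moves the number beyond the scatter, removing the chain entirely is expected to move it further, towards weaker inhibition.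

Compound 4 is therefore estimated at about 2000 nM, with a likely range from 400 nM to 10000 nM. That estimate corresponds to an expected 4.2-fold higher number from compound 3 to compound 4 (0.62 log units; beyond the scatter).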

Compound 4, half-maximal inhibitory concentration: 11000 nM
For compound 4 the middle estimate is 5.5-fold (0.74 log units) below the measured one; measured number outside the range, above it.
By their numbers in this assay, from the lowest: compound 1; then compounds 2 and 3 (each within the scatter of the next); then compound 4.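

In this assay, the group on this aromatic carbon proves far more sensitive to losing the oxygen-linked chain than to changing the chain's end: the step of a 23-fold higher number from compound 3 to compound 4 (1.36 log units; beyond the scatter) is much larger than the step of a 4.0-fold higher number from compound 1 to compound 3 (0.60 log units; beyond the scatter). The group leaving and the group entering each hold a six-membered non-aromatic ring and one hydrogen-bond acceptor, and neither carries a net charge, so the presence of such a ring at this place does not by itself preserve the number. The step of a 92-fold higher number from compound 1 to compound 4 (1.96 log units; beyond the scatter) is the largest seen here, and nothing available explains the size of these changes.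

The compounds shown change the atom attached to the aromatic carbon and the group's size together, so those two contributions cannot be separated. A butylamino group, which puts an amine nitrogen where the oxygen stands while keeping a chain, or a short ethoxy group, which keeps the oxygen while shortening the chain, would help to tell them apart.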